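From Bromobenzyl to Trifluoromethylbenzyl on a Shared Core

The compounds below may be only part of what the source reports. "The series", "measured", "known", "first", "only" and "open" are said of these compounds alone.

Three compounds sharing one core differ only in the group on a saturated chain carbon bound to a sulfur. Compound 1 `Cc1cc(Nc2cc(-c3ccccc3)[nH]n2)n2nc(SCC3CCCCC3)nc2n1`, with a cyclohexyl group, gives > 50000 nM in a functional assay on PC-9 cells (Homo sapiens) for inhibition, read by MTT assay, with a stated time of 72 h (on this read-out lower numbers stand for stronger inhibition and higher numbers for weaker inhibition), and this value is a limit of the assay, not a number. In this assay compound 2 `Cc1cc(Nc2cc(-c3ccccc3)[nH]n2)n2nc(SCc3cccc(Br)c3)nc2n1` gives 8900 nM and compound 3 `Cc1cc(Nc2cc(-c3ccccc3)[nH]n2)n2nc(SCc3ccccc3Br)nc2n1` gives 5630 nM. These two cannot be told apart, as a 1.6-fold lower number from compound 2 to compound 3 (0.20 log units; within the scatter) shows, so compound 3 stands together with compound 2.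

Compound 4 `Cc1cc(Nc2cc(-c3ccccc3)[nH]n2)n2nc(SCc3ccc(C(F)(F)F)cc3)nc2n1` has not yet been measured. It carries 4-(trifluoromethyl)phenyl in place of 2-bromophenyl (4-(trifluoromethyl)phenyl in place of 2-bromophenyl on a saturated chain carbon bound to a sulfur).

Two measured steps are large, an at least 5.6-fold lower number from compound 1 to compound 2 (0.74 log units; beyond the scatter) and an at least 8.8-fold lower number from compound 1 to compound 3 (0.94 log units; beyond the scatter), but both replace cyclohexyl with a bromophenyl group, a different kind of change from this one. The closer guide is the swap of one bromophenyl group for another, a 1.6-fold lower number from compound 2 to compound 3 (0.20 log units; within the scatter), since there too one substituted phenyl group replaces another. For the measured compounds named here, only that single pair supports this comparison, so the expectation is loose. The expected step is a 1.2-fold higher number from compound 3 to compound 4 (0.09 log units; within the scatter), which means no change beyond the scatter. The estimate for compound 4 is 7000 nM, with an expected range from 2500 nM to 20000 nM.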

Compound 4, half-maximal inhibitory concentration: 4240 nM
Beside the measured number, compound 4's estimate is 1.7-fold (0.22 log units) above it; the measured number falls inside the stated range.
By their numbers in this assay, from the lowest: compounds 4, 3 and 2 (each within the scatter of the next, the first and the last beyond it). At a limit, above all of these: compound 1.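

Swapping 2-bromophenyl for 4-(trifluoromethyl)phenyl at this place, on a saturated chain carbon bound to a sulfur, gives a 1.3-fold lower number from compound 3 to compound 4 (0.12 log units; within the scatter) in this assay, so a phenyl group with no bromine and with 10 heavy atoms instead of 7 cannot be told apart from the 2-bromophenyl group, although compound 4 does separate modestly from one bromophenyl compound, with a 2.1-fold lower number from compound 2 to compound 4 (0.32 log units; beyond the scatter), while compound 3 stays within the scatter of both. Compound 4 also extends what the two bromophenyl compounds showed against the cyclohexyl group, since the change to a third substituted phenyl group gives an at least 11-fold lower number from compound 1 to compound 4 (1.07 log units; beyond the scatter). Compound 1 stands at a limit of the assay, so the true size of that step stays unknown: the limit of > 50000 nM in this assay, at which 1 of the 4 values shown sits.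

The compounds shown leave open whether the substituent on the phenyl ring matters at all, as none of them has a plain benzyl group, or a phenyl ring carrying an amine or a carboxylic acid. They also do not show how the numbers would respond to a longer chain between the sulfur and the ring, or to 2-(trifluoromethyl)phenyl or 4-bromophenyl at this place.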